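The source may report more compounds than this note shows. Statements on the series, on what has been measured and on what is new or still open speak of the compounds shown alone.

Measured so far in a functional assay on NUGC-3 cells (Homo sapiens) for inhibition, read by sulforhodamine B assay, with a stated time of 48 h; a higher number here means a weaker inhibitor of growth, a lower number a stronger inhibitor of growth:

compound 1, `COc1ccc(NC(=O)C2c3ccccc3CCN2C(=O)c2ccc(Cl)cc2)cc1`, gives 3630 nM
compound 2, `O=C(Nc1ccc(Cl)cc1)c1nccc2ccccc12`, gives only a limit, > 10000 nM

Going by the values given here, compound 1 is the one member of the pair with a numerical value in this assay. Compound 2 stands at the limit of this assay, with no number beyond it; (the limit of > 10000 nM in this assay, at which 1 of the 2 values shown sits). The two compounds share no single-point change, so nothing is said here about a step between them beyond what their two values show.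

Compound 3, `O=C(Nc1ccc(C(F)(F)F)cc1)c1nccc2ccccc12`, has not been measured. It differs from compound 2 by trifluoromethyl in place of chloro on an aromatic carbon. Among the compounds with values here, compound 2 itself gives no number in this assay, so no step can be anchored, and with no measured step to lean on, the expected step from compound 2 to compound 3 is set at none beyond the scatter, a step that the limit leaves unreadable from compound 2 to compound 3. Compound 3 is therefore expected at 12000 nM, with a range of 3000 nM to 40000 nM, and a fair chance that this assay again reports only a limit for compound 3.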

Compound 3, concentration for 50% growth inhibition: > 10000 nM
Compound 3 was reported as a limit; the forecaster's own chance of this, stated with the estimate: 65%; the middle value is on the limit's open side.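

In this assay compound 3 gives > 10000 nM, a limit and not a number. Compound 2 also stands at a limit, so no step can be read from compound 2 to compound 3: the limit of > 10000 nM in this assay, at which 2 of the 3 values shown sit.

The compounds shown leave open whether trifluoromethyl and chloro in this place differ at all in growth inhibition.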